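Hydroxylation steps on the shared core in this assay

The compounds below may be only part of what the source reports. "The series", "measured", "known", "first", "only" and "open" are said of these compounds alone.

Compound 2 `Oc1ccc(-c2nc3cc(O)c(O)cc3s2)cc1` is the reference point for the next step. In a functional assay on NIH3T3 cells (Mus musculus) for cytotoxicity (on this read-out higher numbers stand for weaker inhibition and lower numbers for stronger inhibition), compound 2 gives 13500 nM. The only comparator, compound 1 `Oc1ccc(-c2nc3cc(O)ccc3s2)cc1`, gives 25000 nM in this assay; the two numbers lie within the usual scatter of each other, so no order between them is claimed.

Compound 3 `Oc1ccc(-c2nc3cc(O)c(O)cc3s2)cc1O` has not yet been measured. It differs from compound 2 by hydroxy in place of hydrogen on an aromatic carbon, placed on an aromatic carbon of a six-membered aromatic ring of carbon only, ortho to a hydroxy group and meta to a large group.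

Among the measured compounds shown here, the one measured step that bears on this change is the same kind of change on the other ring: a 1.9-fold lower number from compound 1 to compound 2 (0.27 log units; within the scatter). That step did not move the number beyond the scatter, and nothing in the measured pair points to a larger effect for a second hydroxy of this kind. The expected step is therefore small, if any, and at most slightly downward: a 1.5-fold lower number from compound 2 to compound 3 (0.18 log units; within the scatter) is expected in this assay.

For compound 3 the estimate in this assay is 9000 nM, with a range from 4000 nM to 25000 nM.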

Compound 3, half-maximal inhibitory concentration: 56500 nM
The estimate for compound 3 lay 6.3-fold (0.80 log units) below the measured number, outside the stated range (above it).
By their numbers in this assay, from the lowest: compounds 2 and 1 (each within the scatter of the next); then compound 3.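

In this assay, hydroxy in place of hydrogen on an aromatic carbon does not behave as a change without consequence at this position, ortho to a hydroxy group and meta to a large group. Here it gives a 4.2-fold higher number from compound 2 to compound 3 (0.62 log units; beyond the scatter), a shift towards weaker inhibition, whereas the same kind of change on the other ring gave only a 1.9-fold lower number from compound 1 to compound 2 (0.27 log units; within the scatter), so the step measured there does not carry over to this position. No measurement at hand bears on the reason for this difference.

Among the compounds shown here, open is whether the step belongs to this hydroxy alone or depends on the hydroxy groups already present in compound 2, as the one step at this position was taken on that single background. Also open, as far as these compounds go, is whether a methoxy group, an amine or a fluorine atom at the same position would move the number in the same direction and by a similar amount, or whether the step is particular to hydroxy.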